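Methoxy Substitution and Cytotoxicity in Two Related Amide Series

This account rests on a few compounds, and the source may have more. Where it says the series, first, only, none or still open, it means among the compounds named here.

In an ADME assay on WI-38 cells (Homo sapiens) for cytotoxicity, read by MTT assay, with a stated time of 72 h (on this read-out higher numbers stand for weaker inhibition and lower numbers for stronger inhibition), compound 1 `O=C(CCc1cccc2c1B(O)OC2)Nc1cccc(-c2ccccc2)c1` gives 12000 nM. Compound 2 `COc1ccc(-c2cccc(NC(=O)CCc3cccc4c3B(O)OC4)c2)cc1` differs from it by one change, (methoxy in place of hydrogen on an aromatic carbon), and in this assay compound 2 gives 1400 nM, so that the step is an 8.6-fold lower number from compound 1 to compound 2 (0.93 log units; beyond the scatter).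

Compound 3 `COc1cccc(-c2cccc(NC(=O)CCc3ccc4c(c3)B(O)OC4)c2)c1` is built on a different core, and the difference between the two cores is not broken down here. In this assay compound 3 gives only a limit, > 100000 nM, namely (the limit of > 100000 nM in this assay, at which 1 of the 3 values shown sits).

The compound that has not yet been measured, compound 4 `COc1cc(OC)cc(-c2cccc(NC(=O)CCc3ccc4c(c3)B(O)OC4)c2)c1`, differs from compound 3 by methoxy in place of hydrogen on an aromatic carbon. Among the compounds with values here, this is the same kind of change as the one from compound 1 to compound 2, not the same: in the earlier pair the entering group sits para to a large group, whereas in compound 4 it sits meta to a large group and meta to a methoxy group, and the starting compound is on the other core.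

Because compound 2 moved from compound 1 by an 8.6-fold lower number from compound 1 to compound 2 (0.93 log units; beyond the scatter), a lower number for compound 4 than for compound 3 is expected in this assay, though compound 3 starts at a limit, so the expected step is an at least 1.6-fold lower number from compound 3 to compound 4 (0.22 log units; that floor lies within the scatter). Compound 4 is therefore estimated at 60000 nM in this assay, within 10000 nM to 300000 nM.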

Compound 4, half-maximal inhibitory concentration: > 100000 nM
Compound 4: no number, only a limit (the forecaster's own chance of this, stated with the estimate: 45%); at least 1.6-fold (0.22 log units) between middle value and limit.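

In this assay compound 4 gives > 100000 nM, which is a limit and not a number. Compound 3 also sits at a limit, so no step from compound 3 to compound 4 can be read: the limit of > 100000 nM in this assay, at which 2 of the 4 values shown sit.

The compounds shown leave open whether methoxy in place of hydrogen changes the number at all on the core shared by compound 3 and compound 4.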